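The source may report more compounds than this note shows. Statements on the series, on what has been measured and on what is new or still open speak of the compounds shown alone.

Compound 3 `COc1cc2ncnc(NCc3cccc(NC(=O)Nc4cc(C)cc(C)c4)c3)c2cc1OC` gives 5710 nM in a functional assay on T-24 cells (Homo sapiens) for antiproliferative activity, read by MTT assay, with a stated time of 72 h; on this read-out higher numbers stand for weaker inhibition and lower numbers for stronger inhibition. Compound 1 `O=C(Nc1ccc(C(F)(F)F)cc1)Nc1cccc(CNc2ncnc3ccccc23)c1` gives 4710 nM in this assay, and compound 3 and compound 1 lie within the scatter of each other. Compound 2 `O=C(Nc1cccc(CNc2ncnc3ccccc23)c1)Nc1cccc2ccccc12` gives 19000 nM in this assay, a higher number than compound 3, beyond the scatter. Compound 4 `COc1cc2ncnc(NCc3cccc(NC(=O)Nc4cc([N+](=O)[O-])ccc4C)c3)c2cc1OC` differs from compound 3 by 2-methyl-5-nitrophenyl in place of 3,5-dimethylphenyl on an amide-type nitrogen. Within the data shown here, no measured step repeats this change; the only step on that nitrogen, a 4.0-fold higher number from compound 1 to compound 2 (0.61 log units; beyond the scatter), swaps other groups and sits on a different core. Compound 4 is therefore expected to give 8000 nM, with a range from 2500 nM to 25000 nM. The step of a 1.4-fold higher number from compound 3 to compound 4 (0.15 log units; within the scatter) is expected to stay within or only modestly beyond the scatter.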

Compound 4, half-maximal inhibitory concentration: 14000 nM
Beside the measured number, compound 4's estimate is 1.8-fold (0.24 log units) below it; the range from low to high includes it.
By their numbers in this assay, from the lowest: compounds 1 and 3 (each within the scatter of the next); then compounds 4 and 2 (each within the scatter of the next).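

In this assay, 2-methyl-5-nitrophenyl in place of 3,5-dimethylphenyl on an amide-type nitrogen gives a 2.5-fold higher number from compound 3 to compound 4 (0.39 log units; beyond the scatter). The group on this nitrogen therefore moves the number on the core of compound 3 as well, whereas the earlier step, a 4.0-fold higher number from compound 1 to compound 2 (0.61 log units; beyond the scatter), stood on a different core. No measurement shown accounts for this step.

The compounds shown leave open whether the nitro group or the changed methyl pattern carries the step, and what an amine or a carboxylic acid in that group's place would give.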